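The compounds below may be only part of what the source reports. "The series", "measured", "known", "first", "only" and "open" are said of these compounds alone.

Measured compounds:
Compound 1, `COc1ccc(NCc2nc3ccccc3[nH]2)cc1`: 33.3%
Compound 2, `O=[N+]([O-])c1ccc2nc(CNc3ccc(Br)cc3)[nH]c2c1`: 22.2%

Both compounds share a core and differ in what hangs on the outer ring and on the fused ring. In a functional assay on the whole organism (strain albino) for inhibition, with Rattus norvegicus as the target, read by paw edema, with a stated time of 180 min, at a dose of 100 mg/kg by the oral route (a lower number here means less inhibition, a higher number more inhibition at the dose given (going by the name of the read-out)), compound 1 gives 33.3%, and in this assay compound 2 gives 22.2%. Compound 2 thus stands at the lower of the two numbers, and the gap to compound 1, its nearest neighbour, lies beyond the usual scatter of this kind of measurement.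

Compound 3, `Brc1ccc(NCc2nc3ccccc3[nH]2)cc1`, is made from compound 2 by a single change: hydrogen in place of nitro on an aromatic carbon. For the measured compounds named here, no pair of measured compounds differs in just one place, so there is no measured step to lean on. Compound 1 also lacks the nitro and sits higher than compound 2, but it carries a methoxy rather than a bromine, so it gives only a loose hint.

The expected step in this assay from compound 2 to compound 3 is a number 5.8 percentage points higher from compound 2 to compound 3 (within the scatter), a small rise that may not exceed the scatter. Compound 3 is therefore estimated at 28%, with a likely range from 12% to 44%.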

Compound 3, a percentage reported as inhibition, in the whole organism at one dose (the size of the read-out at that dose, not a potency): 29.4%
Beside the measured number, compound 3's estimate is 1.4 percentage points below it; low and high end bracket the measured number.
By their numbers in this assay, from the lowest: compounds 2, 3 and 1 (each within the scatter of the next, the first and the last beyond it).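

In this assay, for the compounds shown here, hydrogen in place of nitro on an aromatic carbon gives a number 7.2 percentage points higher from compound 2 to compound 3 (within the scatter), so this position now has a measured step in which only one thing changes, and that step cannot be told apart from the spread of repeated measurements. Compound 3 also links to compound 1 through a single change in another place: bromo in place of methoxy on an aromatic carbon gives a number 3.9 percentage points lower from compound 1 to compound 3 (within the scatter), so at this dose neither of the two single changes stands out from the scatter, and neither the nitro nor the bromo can be said to matter for the read-out. Nothing measured here speaks to what lies behind either step.

Still open, going by these compounds, is whether a different group on the same aromatic carbon, such as an amine or a carboxylic acid, would shift the number beyond the scatter, and whether a nitro group there would give a similar step with methoxy on the outer ring instead of bromo. On these data alone, each number also comes from a single dose, so how these compounds would compare across a range of doses remains unknown.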